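The source may report more compounds than this note shows. Statements on the series, on what has been measured and on what is new or still open speak of the compounds shown alone.

In an ADME assay on MT4 cells (Homo sapiens) for cytotoxicity, read by MTT assay, with a stated time of 5 days (on this read-out higher numbers stand for lower toxicity in this test and lower numbers for higher toxicity in this test), three compounds have been measured:

Compound 1 `O=C1N(Cc2ccc(Cl)cc2Cl)c2cccn2S(=O)(=O)N1Cc1ccccc1` gives 218000 nM.
Compound 2 `O=C1N(Cc2cccc(Cl)c2)c2cccn2S(=O)(=O)N1Cc1ccccc1` gives 196000 nM.
Compound 3 `N#Cc1ccccc1CN1C(=O)N(Cc2ccccc2)S(=O)(=O)n2cccc21` gives > 318000 nM.

For compound 3 the value is a limit of the assay and not a number (the limit of > 318000 nM in this assay, at which 1 of the 3 values shown sits). Compound 3 therefore stands at the edge of what this assay can report, with no measured number of its own.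

Compound 4 `N#CCN1C(=O)N(Cc2ccccc2)S(=O)(=O)n2cccc21` has not yet been measured. It differs from compound 3 in one place: cyano in place of 2-cyanophenyl on a saturated chain carbon bound to an amide-type nitrogen in a ring. The measured steps that touch the same place are an at least 1.4-fold higher number from compound 1 to compound 3 (0.16 log units; that floor lies within the scatter) and an at least 1.6-fold higher number from compound 2 to compound 3 (0.21 log units; that floor lies within the scatter), and the remaining step, a 1.1-fold lower number from compound 1 to compound 2 (0.05 log units; within the scatter), also sits within the scatter. Going by the values given here, all three swaps exchanged one substituted phenyl for another, whereas the change to compound 4 removes the six-membered aromatic ring altogether, a kind of step none of the measured pairs covers.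

Within those data, no step beyond the scatter is expected, so the estimated step is a number no higher from compound 3 to compound 4 (the limit leaves the size open). Compound 4 is accordingly estimated at 318000 nM, with a range from 150000 nM to 650000 nM, and a limit rather than a number is thought likely.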

Compound 4, half-maximal cytotoxic concentration: 180000 nM
The estimate for compound 4 lay 1.8-fold (0.25 log units) above the measured number, and the stated range covers the measured number.
By their numbers in this assay, from the lowest: compounds 4, 2 and 1 (each within the scatter of the next). At a limit, above all of these: compound 3.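

Removing the six-membered aromatic ring on this saturated chain carbon, a kind of change the earlier swaps between phenyl groups did not cover, leaves the number in this assay within the scatter of the two chlorine-bearing compounds: a 1.1-fold lower number from compound 2 to compound 4 (0.04 log units; within the scatter) and a 1.2-fold lower number from compound 1 to compound 4 (0.08 log units; within the scatter). The third step, an at least 1.7-fold lower number from compound 3 to compound 4 (0.24 log units; that floor lies within the scatter), is the only one that could prove larger, and its floor does not settle that. Compound 3 stands at a limit and not at a number: the limit of > 318000 nM in this assay, at which 1 of the 4 values shown sits.

On these data alone, how an amine, a carboxylic acid or a longer chain ending in a nitrile would read at this place remains open. As far as these compounds go, whether a plain methyl here would read like cyanomethyl also stays open.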